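This account rests on a few compounds, and the source may have more. Where it says the series, first, only, none or still open, it means among the compounds named here.

Measured so far in a functional assay with Oryctolagus cuniculus as the target; on this read-out lower numbers stand for stronger inhibition and higher numbers for weaker inhibition:
- compound 1 `COc1ccc(-c2nc(N=C(N)N)sc2-c2ccc(OC)cc2)cc1`: 31000 nM
- compound 2 `COc1ccc(-c2nc(CNC(=O)NC(C)C)sc2-c2ccc(OC)cc2)cc1`: 42 nM

Compound 1 stands highest of the two numbers in this assay; the nearest is compound 2, reached by a 740-fold lower number from compound 1 to compound 2 (2.87 log units; beyond the scatter). Both share the same core, and the two differ only in the group carried on the aromatic carbon of that core.

Compound 3 `CCN(CC)C(=O)c1nc(-c2ccc(OC)cc2)c(-c2ccc(OC)cc2)s1` is not yet measured. It differs from compound 1 by a group of 7 heavy atoms (5 carbon, 1 nitrogen, 1 oxygen; no ring) in place of a group of 4 heavy atoms (1 carbon, 3 nitrogen; no ring), on an aromatic carbon; the diethylcarbamoyl sits on an aromatic carbon of a five-membered aromatic ring with 1 nitrogen and 1 sulfur, two ring bonds from the two ring atoms that each bear a 4-methoxyphenyl group.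

Going by the values given here, the only step that bears on this change is a 740-fold lower number from compound 1 to compound 2 (2.87 log units; beyond the scatter), where the same group of 4 heavy atoms (1 carbon, 3 nitrogen) was exchanged for another acyclic group with 0 rings. Among the compounds with values here, the group entering compound 3 is not the one entering compound 2, so that step is a guide to direction more than to size. Compound 3 is therefore expected to show a lower number than compound 1, a step of a 31-fold lower number from compound 1 to compound 3 (1.49 log units; beyond the scatter), less than the step to compound 2. The estimate for compound 3 in this assay is 1000 nM, within 100 nM to 10000 nM.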

Compound 3, half-maximal inhibitory concentration: < 10 nM
Compound 3: no number, only a limit; the forecaster's own chance of this, stated with the estimate: 5%; at least 100-fold (2.00 log units) between middle value and limit.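

In this assay compound 3 carries a limit of the assay and not a number: the limit of < 10 nM in this assay, at which 1 of the 3 values shown sits.

On the aromatic carbon next to the ring nitrogen and next to the ring sulfur, diethylcarbamoyl in place of the group in compound 1, which has 2 hydrogen-bond donors, gives an at least 3100-fold lower number from compound 1 to compound 3 (3.49 log units; beyond the scatter). Compound 2 had already shown that this position responds strongly to a change of group, while compound 3 shows that a group with 0 hydrogen-bond donors can also reach the low end of the series. The two replacement groups also separate from each other, with an at least 4.2-fold lower number from compound 2 to compound 3 (0.62 log units; beyond the scatter), so the size of the change depends on which group enters and not only on which group leaves.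

From the compounds shown here alone, how far compound 3 lies past its limit remains open, and with it the full size of both new steps. Also open, going by these compounds, is whether a dimethylamide, a pyrrolidine amide, a carboxylic acid or a primary amine on this carbon would hold a number as low, since the comparison so far rests on three groups in this one assay.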